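This account rests on a few compounds, and the source may have more. Where it says the series, first, only, none or still open, it means among the compounds named here.

In an ADME assay on HepG2 cells (Homo sapiens) for cytotoxicity, read by luminescence, with a stated time of 72 h (a lower number here means that less compound is needed, a higher number that more compound is needed for the effect), compound 1 (`CCOC(=O)c1c(-c2cccc(-c3ccccc3)c2)[nH]c2cc(OC)ccc2c1=O`) gives > 21500 nM, which is a limit of the assay and not a number. Compound 2 (`CCOC(=O)c1c(-c2cccc(N(C)C)c2)[nH]c2cc(OC)ccc2c1=O`) gives > 21500 nM, also a limit. Compound 3 (`CCOC(=O)c1c(-c2cccc(CO)c2)[nH]c2cc(OC)ccc2c1=O`) gives > 21500 nM, again a limit. Compound 1 therefore has no exact position in the series, and the whole picture so far is the limit of > 21500 nM in this assay, at which 3 of the 3 values shown sit.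

Compound 4 (`CCOC(=O)c1c(-c2cccc(-c3ccccc3)c2)[nH]c2cc(OC)c(OC)cc2c1=O`) differs from compound 1 in one place: methoxy in place of hydrogen on an aromatic carbon. This is methoxy in place of hydrogen on an aromatic carbon, ortho to a methoxy group.

Within the data shown here, the only measured steps are a step that the two limits leave unreadable from compound 1 to compound 2, a step that the two limits leave unreadable from compound 1 to compound 3 and a step that the two limits leave unreadable from compound 2 to compound 3. Each exchanges phenyl, dimethylamino or hydroxymethyl on an aromatic carbon, so none of them adds a methoxy group, and none has a readable size. The expectation rests on compound 1, whose limit is > 21500 nM, and on the same limit recurring across the measured steps. No step beyond the scatter, in either direction, is therefore expected in this assay. The expected step is a step that the limit leaves unreadable from compound 1 to compound 4, an estimate that is only loosely anchored. The estimated value for compound 4 is 25000 nM, with an expected range from 10000 nM to 60000 nM, and the assay may well report only a limit again.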

Compound 4, half-maximal effective concentration: > 21500 nM
Compound 4: a limit, no number; the forecaster's own chance of this, stated with the estimate: 85%; the middle value is on the limit's open side.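

In this assay compound 4 gives > 21500 nM, a limit of the assay and not a number. Among these compounds, compound 1 also stands at a limit, so no step between compound 1 and compound 4 can be read. The compounds shown leave open what concentration any of them needs for the effect, and whether methoxy in place of hydrogen changes it, as all share one result: the limit of > 21500 nM in this assay, at which 4 of the 4 values shown sit.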